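Bromine on the Pendant Ring and on the Core

The source may hold more compounds than are shown below. What is called first, only, known or untested is meant among the compounds shown, and "the series" means these compounds.

Measured so far:
compound 1 `O=C(CCc1ccccc1)Nc1nc2ccccc2c(=O)s1`: 422 nM
compound 2 `O=C(CCCc1ccccc1)Nc1nc2ccccc2c(=O)s1`: 229 nM
compound 3 `O=C(CCc1ccccc1Br)Nc1nc2ccccc2c(=O)s1`: only a limit, > 10000 nM

In an assay on membranes from brain for displacement of a labelled ligand from adenosine receptor A1 (Rattus norvegicus), read by scintillation counting, with a stated time of 90 min (on this read-out lower numbers stand for stronger inhibition and higher numbers for weaker inhibition), compound 1 gives 422 nM and compound 2 gives 229 nM. Compound 2 differs from compound 1 by benzyl in place of phenyl on a saturated chain carbon, two bonds along the chain from a carbonyl carbon, and the step is a 1.8-fold lower number from compound 1 to compound 2 (0.27 log units; within the scatter). For compound 3 the assay reports only a limit, > 10000 nM. Compound 3 differs from compound 1 by bromo in place of hydrogen on an aromatic carbon, a step of an at least 23-fold higher number from compound 1 to compound 3 (1.37 log units; beyond the scatter), ending at the limit of > 10000 nM in this assay, at which 1 of the 3 values shown sits.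

Compound 4 `O=C(CCCc1ccccc1)Nc1nc2ccc(Br)cc2c(=O)s1` has not been measured. It differs from compound 2 by bromo in place of hydrogen on an aromatic carbon, the same kind of change, but the place is not the same: in compound 3 the bromo sits ortho to a large group, whereas in compound 4 it sits on a ring that is part of a fused or bridged system of two rings, meta to a fused ring and para to a fused ring. Going by the values given here, the step from compound 2 is expected to be a 1.5-fold higher number from compound 2 to compound 4 (0.18 log units; within the scatter), an expectation that rests on the only measured bromo step an at least 23-fold higher number from compound 1 to compound 3 (1.37 log units; beyond the scatter) having been made at a different place. Compound 4 is therefore estimated at 350 nM, between 60 nM and 3000 nM.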

Compound 4, inhibition constant: > 10000 nM
Compound 4 gave a limit, no number; the forecaster's own chance of this, stated with the estimate: 15%; middle value at least 28-fold (1.45 log units) away from the limit.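

In this assay compound 4 gives only a limit, > 10000 nM. The step is an at least 43-fold higher number from compound 2 to compound 4 (1.64 log units; beyond the scatter), so bromo in place of hydrogen on an aromatic carbon moved the number up beyond the scatter on both cores, although at different places: the same change on two cores in this assay, an at least 23-fold higher number (1.37 log units; beyond the scatter) from compound 1 to compound 3 and an at least 43-fold higher number (1.64 log units; beyond the scatter) from compound 2 to compound 4; the limit leaves it open whether they differ. This shows that the loss carried over from one core to the other in these two pairs, but not how large either step really is, nor that any bromo on any ring of this series would do the same: the limit of > 10000 nM in this assay, at which 2 of the 4 values shown sit.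

The compounds shown leave open whether fluoro, chloro or methyl at these same places would give a number rather than a limit. They also leave open how bromo would behave with a longer chain.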